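Replacing the ether group of compound 1

This account rests on a few compounds, and the source may have more. Where it says the series, first, only, none or still open, it means among the compounds named here.

Measured so far in a physicochemical assay for solubility; on this read-out higher numbers stand for higher solubility and lower numbers for lower solubility:
- compound 1 `C[C@H](Nc1ccc(C#N)n(C)c1=O)c1cc2cc(Cl)c(OCC3CC3)cc2[nH]c1=O` gives 530 nM
- compound 2 `CN1CCCC(NCc2cc3cc(Cl)ccc3[nH]c2=O)C1=O` gives 94000 nM

Compound 1 holds the lower of the two numbers, and compound 2 stands far higher, a gap well beyond the usual scatter. Next in line is compound 3 `C[C@H](Nc1ccc(C#N)n(C)c1=O)c1cc2cc(Cl)c(O[C@H](C)c3ccccn3)cc2[nH]c1=O`, not yet measured. It carries 1-(pyridin-2-yl)ethyl in place of cyclopropylmethyl on an oxygen on an aromatic ring. The entering group brings a six-membered aromatic ring with 1 hetero atom and a defined stereocentre.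

Among the measured compounds shown here, the two measured compounds offer no step for a single change, so the expectation rests only on the structural change and on compound 1 at 530 nM as the starting point. A small downward move is expected, one that may not clear the usual scatter. The expected size is a 1.8-fold lower number from compound 1 to compound 3 (0.25 log units; within the scatter) on this read-out. In this assay compound 3 is estimated at 300 nM (expected range 60 nM to 1300 nM).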

Compound 3, solubility: 1600 nM
Compound 3: the middle estimate sits 5.3-fold (0.73 log units) below what was measured, outside the stated range (above it).
By their numbers in this assay, from the lowest: compound 1; then compound 3; then compound 2.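

Position notes: the group on an oxygen on an aromatic ring is now shown to move the read-out, with 1-(pyridin-2-yl)ethyl in place of cyclopropylmethyl giving a 3.0-fold higher number from compound 1 to compound 3 (0.48 log units; beyond the scatter) in this assay. Among the compounds shown here, this is the first single-place step, and it runs upward although the entering group is the larger one by heavy-atom count and brings a six-membered aromatic ring with 1 hetero atom, a hydrogen-bond acceptor and a defined stereocentre, so this oxygen substituent can be enlarged on the core of compound 1 without a loss on this read-out. No measurement on hand explains the rise, and it cannot be assigned to any one of those features.

Still open, from the compounds shown here alone, is which feature carries the step: a 1-phenylethyl group would test the ring nitrogen, a pyridin-2-ylmethyl group the branching methyl, and the opposite stereoisomer of 1-(pyridin-2-yl)ethyl the stereocentre. Also open, going by these compounds, is how the read-out responds on this oxygen to a 2-(dimethylamino)ethyl chain or a group ending in a carboxylic acid.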